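Working notes on compounds 1 to 3

The source may report more compounds than this note shows. Statements on the series, on what has been measured and on what is new or still open speak of the compounds shown alone.

Measured so far:
Compound 1, `O=C1C2CCCN2C(=O)N1CCN1CCN(c2ccc([N+](=O)[O-])cc2)CC1`. In an assay on isolated protein for binding affinity to Adrenergic receptor alpha-1 (Rattus norvegicus), read by radioligand binding (a higher number here means a weaker inhibitor, a lower number a stronger inhibitor), compound 1 gives only a limit, > 10000 nM.
Compound 2, `O=C1C2CCCCN2C(=O)N1CCCCN1CCN(c2ccccc2)CC1`. In this assay compound 2 gives 18.6 nM.

Among the compounds with values here, compound 2 carries the only number in the set. The entry for compound 1 is a limit and not a number (the limit of > 10000 nM in this assay, at which 1 of the 2 values shown sits). Next in line is compound 3, `O=C1C2CCCCN2C(=O)N1CCCCN1CCN(c2ccc(F)cc2)CC1`, which differs from compound 2 by fluoro in place of hydrogen on an aromatic carbon. Within the data shown here, no measured pair shows this change, so its size cannot be read off the data; the expected step in this assay is a 1.2-fold lower number from compound 2 to compound 3 (0.09 log units; within the scatter), which would stay inside the usual scatter. Compound 3 is accordingly estimated at 15 nM, with a range from 6 nM to 45 nM.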

Compound 3, inhibition constant: 10.4 nM
Estimate against measurement, compound 3: 1.4-fold (0.16 log units) above; low and high end bracket the measured number.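

Within the data shown here, the first readable step is phenyl to 4-fluorophenyl, and in this assay it comes to a 1.8-fold lower number from compound 2 to compound 3 (0.25 log units; within the scatter). The two compounds therefore cannot be told apart in this read-out, so one fluoro group on this aromatic carbon, para to a large group, is accepted without a step beyond the scatter. Nothing shown gives a cause for this step.

Among these compounds, compound 1 remains a limit, > 10000 nM, and differs from compound 2 in more than one place, so it gives no step to set beside this one. Open, on these data alone, is how chloro or methoxy on the same aromatic carbon would read, and whether a group larger than fluoro at this place would give a step beyond the scatter.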